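The compounds below may be only part of what the source reports. "The series", "measured", "known", "first", "only" and "open" are said of these compounds alone.

Compound 1 `CCCNC(=S)SCc1nc2ccccc2[nH]1`: 2290 nM
Compound 2 `O=C(CC(SC(=S)N1CCCC1)c1ccccc1)c1ccccc1`: 1670 nM

Both numbers come from a functional assay on the whole organism for inhibition, with Cicer arietinum as the target, with a stated time of 7 days; a lower number here means a stronger inhibitor, a higher number a weaker inhibitor. In this assay compound 2 gives 1670 nM, and this lies within the usual scatter of the value of compound 1, so the two compounds cannot be told apart on these data. Compound 3 `O=C(CC(SC(=S)N1CCOCC1)c1ccccc1)c1ccccc1` differs from compound 2 in a single place: morpholin-4-yl in place of pyrrolidin-1-yl on a thiocarbonyl carbon. Going by the values given here, no measured pair shows what such a change does here, so no shift beyond the scatter is expected in either direction. Compound 3 is therefore estimated at 1800 nM, with a range from 700 nM to 4500 nM. The step this estimate means is expected to be a 1.1-fold higher number from compound 2 to compound 3 (0.03 log units; within the scatter).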

Compound 3, half-maximal inhibitory concentration: 1650 nM
The estimate for compound 3 lay 1.1-fold (0.04 log units) above the measured number, within the range that was stated.
By their numbers in this assay, from the lowest: compounds 3, 2 and 1 (each within the scatter of the next).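

In this assay, morpholin-4-yl in place of pyrrolidin-1-yl on a thiocarbonyl carbon gives a 1.0-fold lower number from compound 2 to compound 3 (0.01 log units; within the scatter) and so leaves compounds 2 and 3 indistinguishable. At this position, then, a six-membered ring carrying a hydrogen-bond acceptor gives a number that cannot be told apart from that of the five-membered ring without one. No other measurement here helps to explain this match.

Two rings cannot show whether every group on this carbon would behave the same way. A piperazine or an open-chain diethylamino group in the same place would test this further.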